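Swapping butylcarbonyl for methyl on an aromatic oxygen

A few compounds are considered here, and "the series" means these few. Any claim that something is new, unique, unknown or untested is made for them only; others in the source may bear on it.

- compound 1 `CC(=O)Oc1ccc2oc(/C=C/[S+](C)[O-])cc(=O)c2c1`: 4100 nM
- compound 2 `CCCC(=O)Oc1ccc2oc(/C=C/[S+](C)[O-])cc(=O)c2c1`: 2200 nM
- compound 3 `CCCCC(=O)Oc1ccc2oc(/C=C/[S+](C)[O-])cc(=O)c2c1`: 2400 nM

In a functional assay on A549 cells (Homo sapiens) for cytotoxicity, with a stated time of 48 h (a lower number here means a stronger inhibitor, a higher number a weaker inhibitor), compound 3 gives 2400 nM, which cannot be separated from the other two compounds. The data show a 1.7-fold lower number from compound 1 to compound 3 (0.23 log units; within the scatter) and a 1.1-fold higher number from compound 2 to compound 3 (0.04 log units; within the scatter). Compound 4 `COc1ccc2oc(/C=C/[S+](C)[O-])cc(=O)c2c1` has methyl in place of butylcarbonyl on an oxygen on an aromatic ring. Going by the values given here, no measured step makes this exchange. The nearest evidence is chain length on the carbonyl, where a 1.9-fold lower number from compound 1 to compound 2 (0.27 log units; within the scatter) is also small. A step beyond the scatter is therefore not expected, though direct evidence is lacking. The expected step is a 1.5-fold higher number from compound 3 to compound 4 (0.16 log units; within the scatter). For compound 4 the estimated value is 3500 nM, with an expected range of 1300 nM to 10000 nM.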

Compound 4, half-maximal inhibitory concentration: 1600 nM
The estimate for compound 4 lay 2.2-fold (0.34 log units) above the measured number, and the stated range covers the measured number.
By their numbers in this assay, from the lowest: compounds 4, 2, 3 and 1 (each within the scatter of the next, the first and the last beyond it).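

Methyl on this aromatic oxygen holds up against the longer esters in this assay, with a 1.5-fold lower number from compound 3 to compound 4 (0.18 log units; within the scatter) and a 1.4-fold lower number from compound 2 to compound 4 (0.14 log units; within the scatter) in the two comparisons, so a carbonyl on this oxygen is not needed for a number at this level. Only against the acetyl ester does the exchange clear the scatter, and modestly, with a 2.6-fold lower number from compound 1 to compound 4 (0.41 log units; beyond the scatter) as the step. Nothing available explains this result. The compounds shown leave open how a free hydroxyl or a benzyl ether on this oxygen would read in this assay on the same core.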